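Working notes: from compound 2 to compound 3

A few compounds are considered here, and "the series" means these few. Any claim that something is new, unique, unknown or untested is made for them only; others in the source may bear on it.

- compound 1 `O=C(Nc1nnc(-c2cccc(O)c2O)s1)c1ccc(Cl)cc1`: 18700 nM
- compound 2 `Cc1ccc(C(=O)Nc2nnc(-c3cccc(O)c3O)s2)cc1`: 33200 nM

In an ADME assay on MRC5 cells (Homo sapiens) for cytotoxicity, read by MTT assay, with a stated time of 72 h (on this read-out higher numbers stand for weaker inhibition and lower numbers for stronger inhibition), compound 2 gives 33200 nM, within the scatter of compound 1. Compound 3 `O=C(Nc1nnc(-c2cccc(O)c2O)s1)C1CCCCC1` carries the change (cyclohexyl in place of 4-methylphenyl on a carbonyl carbon), with cyclohexyl in place of 4-methylphenyl on a carbonyl carbon. Within the data shown here, the only measured step, a 1.8-fold higher number from compound 1 to compound 2 (0.25 log units; within the scatter), is methyl in place of chloro on an aromatic carbon. It keeps the six-membered aromatic ring, so it bears on this change only loosely. No step beyond the scatter is expected in this assay, and the data give no direction. The expected step is a 1.1-fold lower number from compound 2 to compound 3 (0.04 log units; within the scatter). For compound 3 the estimated value is 30000 nM, with an expected range of 12000 nM to 75000 nM.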

Compound 3, half-maximal inhibitory concentration: 70300 nM
Compound 3: middle estimate off by 2.3-fold (0.37 log units), on the low side; measured number inside the range.
By their numbers in this assay, from the lowest: compounds 1 and 2 (each within the scatter of the next); then compound 3.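

In this assay, cyclohexyl in place of 4-methylphenyl on a carbonyl carbon gives a 2.1-fold higher number from compound 2 to compound 3 (0.33 log units; beyond the scatter) and cyclohexyl in place of 4-chlorophenyl gives a 3.8-fold higher number from compound 1 to compound 3 (0.58 log units; beyond the scatter) as well, both modest and in the same direction. At this position, exchanging the aromatic ring for the non-aromatic one moves the number beyond the scatter, which methyl in place of chloro did not. No measured evidence bears on the reason for this shift. Open, as far as these compounds go, is whether a longer chain, or an amine or carboxylic acid on the ring, would move the number further.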